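From Phenylethenyl to Dimethylaminophenyl on a Shared Core

This account rests on a few compounds, and the source may have more. Where it says the series, first, only, none or still open, it means among the compounds named here.

Three compounds share one core and differ only in the group on a double-bonded chain carbon bound to a double-bonded ring carbon. In a functional assay on HeLa cells (Homo sapiens) for cytotoxicity, read by sulforhodamine B assay, with a stated time of 48 h (on this read-out higher numbers stand for weaker inhibition and lower numbers for stronger inhibition), compound 1 `CC(=O)OC[C@H]1O[C@@H](n2cc(CN3C(=O)/C(=C\c4ccccc4)c4ccccc43)nn2)[C@H](OC(C)=O)[C@@H](OC(C)=O)[C@@H]1OC(C)=O` gives 33300 nM, compound 2 `COc1ccc(/C=C2\C(=O)N(Cc3cn([C@@H]4O[C@H](COC(C)=O)[C@@H](OC(C)=O)[C@H](OC(C)=O)[C@H]4OC(C)=O)nn3)c3ccccc32)cc1OC` gives 63400 nM, and compound 3 `CC(=O)OC[C@H]1O[C@@H](n2cc(CN3C(=O)/C(=C\C=C\c4ccccc4)c4ccccc43)nn2)[C@H](OC(C)=O)[C@@H](OC(C)=O)[C@@H]1OC(C)=O` gives 98100 nM, the highest of the three numbers. The measured steps were a 1.9-fold higher number from compound 1 to compound 2 (0.28 log units; within the scatter), a 2.9-fold higher number from compound 1 to compound 3 (0.47 log units; beyond the scatter) and a 1.5-fold higher number from compound 2 to compound 3 (0.19 log units; within the scatter).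

Compound 4 `CC(=O)OC[C@H]1O[C@@H](n2cc(CN3C(=O)/C(=C\c4ccc(N(C)C)cc4)c4ccccc43)nn2)[C@H](OC(C)=O)[C@@H](OC(C)=O)[C@@H]1OC(C)=O` is compound 3 with 4-(dimethylamino)phenyl in place of 2-phenylethenyl on a double-bonded chain carbon bound to a double-bonded ring carbon. Among the compounds with values here, two measured steps bear on this change: the step of a 2.9-fold higher number from compound 1 to compound 3 (0.47 log units; beyond the scatter) shows what the 2-phenylethenyl group did when it replaced phenyl, and the step of a 1.9-fold higher number from compound 1 to compound 2 (0.28 log units; within the scatter) shows that substituents on a phenyl ring changed the number only within the scatter. Removing the ethenyl link should roughly undo the first step, and a single ring substituent should count for little. Compound 4 is therefore expected to show a modest decrease, a 2.2-fold lower number from compound 3 to compound 4 (0.34 log units; beyond the scatter). The estimate for compound 4 in this assay is 45000 nM, with a range from 20000 nM to 100000 nM.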

Compound 4, half-maximal inhibitory concentration: 25000 nM
Compound 4: middle estimate off by 1.8-fold (0.26 log units), on the high side, within the range that was stated.
By their numbers in this assay, from the lowest: compounds 4, 1, 2 and 3 (each within the scatter of the next, the first and the last beyond it).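

In this assay, 4-(dimethylamino)phenyl in place of 2-phenylethenyl gave a 3.9-fold lower number from compound 3 to compound 4 (0.59 log units; beyond the scatter) and so brought a step beyond the scatter in the downward direction at this position. Differences among substituted phenyl groups also proved able to pass the scatter, with a 2.5-fold lower number from compound 2 to compound 4 (0.40 log units; beyond the scatter) standing against the step from the unsubstituted phenyl to the 3,4-dimethoxyphenyl group, which had stayed within it. Dimethylamino in place of hydrogen on an aromatic carbon gave only a 1.3-fold lower number from compound 1 to compound 4 (0.12 log units; within the scatter) and so leaves compound 1 and compound 4 indistinguishable in this read-out.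

Nothing given here explains these differences. The compounds shown leave open whether a primary amine, a carboxylic acid or a longer alkyl chain on the phenyl ring would separate from compound 1 in this assay.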